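Core methylation in the sulfonyl-aryl series: compound 4

This account rests on a few compounds, and the source may have more. Where it says the series, first, only, none or still open, it means among the compounds named here.

Compound 1 `CC(C)(C)OC(=O)N1CCC(Oc2ncnc3c2CCN3c2ccc(S(C)(=O)=O)cc2F)CC1` is the reference point of this small set. In a functional assay on CHO-K1 cells with Glucose-dependent insulinotropic receptor (Homo sapiens) as the target, read by a luciferase reporter, with a stated time of 5 h (on this read-out lower numbers stand for smaller maximal responses and higher numbers for larger maximal responses), compound 1 gives 139%, the highest of the three measured numbers. Compound 2 `CS(=O)(=O)c1ccc(N2CCc3c(OC4CCN(C(=O)OCCF)CC4)ncnc32)c(F)c1` gives 86% and compound 3 `CS(=O)(=O)c1ccc(N2CCc3c(OC4CCN(C(=S)Sc5ccccc5)CC4)ncnc32)c(F)c1` gives 103%. Both measured steps away from compound 1 fall: a number 53 percentage points lower from compound 1 to compound 2 (beyond the scatter) and a number 36 percentage points lower from compound 1 to compound 3 (beyond the scatter), while a number 17 percentage points higher from compound 2 to compound 3 (beyond the scatter) separates the two lower compounds. All three steps concern the group on the amine nitrogen in the ring; none of them touches the shared core.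

Compound 4 `Cc1nc(OC2CCN(C(=O)OC(C)(C)C)CC2)c2c(n1)N(c1ccc(S(C)(=O)=O)cc1F)CC2` differs from compound 1 at the shared core: methyl in place of hydrogen on an aromatic carbon. Among the compounds with values here, no measured step bears on this change, so the measured steps give no direction for it. Within the data shown here, with no relevant step to draw on, the expectation for compound 4 is a number close to that of compound 1, meaning a step of a number 9 percentage points lower from compound 1 to compound 4 (within the scatter) that is not beyond the scatter. Compound 4 is therefore estimated at 130% in this assay, with a range from 100% to 160%.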

Compound 4, largest response reached (reported as percent of maximum), in percent of the reference or control that the assay uses: 69%
Beside the measured number, compound 4's estimate is 61 percentage points above it, and the stated range ends above it.
By their numbers in this assay, from the lowest: compound 4; then compound 2; then compound 3; then compound 1.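

In this assay there is a number 70 percentage points lower from compound 1 to compound 4 (beyond the scatter) with methyl in place of hydrogen on an aromatic carbon, so this position between two ring nitrogen atoms is not a silent one. Within the data shown here, the group on the amine nitrogen in the ring is the same in both compounds, so the shared core, untouched by the earlier steps, also bears on the maximal response, and a change of one heavy atom there is enough to move it beyond the scatter. Nothing at hand accounts for this effect of the methyl.

Still open, from the compounds shown here alone, is whether an amine, a methoxy group or a longer chain such as ethyl on this aromatic carbon would keep the response of compound 1 or lower it further. Also open, going by these compounds, is whether the methyl has a similar effect with the 2-fluoroethyl group of compound 2 in place of tert-butyl.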